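Bromine removal in a hydrazone series at the assay limit

The source may hold more compounds than are shown below. What is called first, only, known or untested is meant among the compounds shown, and "the series" means these compounds.

Compound 1, `COc1ccc2c(c1)c(/C=N\NC(=O)c1c[nH]c3ccc(Br)cc13)cn2Cc1ccc(Cl)cc1`, gives in a functional assay on LNCaP cells (Homo sapiens) for cytotoxicity (on this read-out lower numbers stand for stronger inhibition and higher numbers for weaker inhibition), only a limit, > 100000 nM.
Compound 2, `COc1ccc2c(c1)c(/C=N\NC(=O)c1c[nH]c3ccccc13)cn2Cc1ccc(Cl)cc1`, gives in this assay only a limit, > 100000 nM.
Compound 3, `COc1ccc(Cn2cc(/C=N\NC(=O)c3c[nH]c4ccc(Br)cc34)c3ccc(F)cc32)cc1`, gives in this assay only a limit, > 100000 nM.

The account concerns three measured compounds and one that has not yet been measured, compound 4, `COc1ccc(Cn2cc(/C=N\NC(=O)c3c[nH]c4ccccc34)c3ccc(F)cc32)cc1`. Compound 1 and compound 2 share a core and differ in one place: hydrogen in place of bromo on an aromatic carbon. The resulting step, a step that the two limits leave unreadable from compound 1 to compound 2, cannot be sized, since both ends of it are limits rather than numbers. Compound 3 carries a different core; how the core of compound 3 differs from the core of compound 1 is not broken down here. Compound 4 stands to compound 3 exactly as compound 2 stands to compound 1, by the same change at the same place: hydrogen in place of bromo on an aromatic carbon. In all, this change occurs twice among the four compounds.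

Among the measured compounds shown here, the only evidence on the measured step is the limit of > 100000 nM in this assay, at which 3 of the 3 values shown sit. For the measured compounds named here, every value so far is a limit, so no measured change has been resolved anywhere in this set. On that basis the step from compound 3 to compound 4 is expected to be small and itself unreadable, a number no higher from compound 3 to compound 4 (the limit leaves the size open), because the corresponding step that the two limits leave unreadable from compound 1 to compound 2 is hidden by the same limit. Compound 4 is therefore estimated at 100000 nM in this assay, with an expected range from 50000 nM to 300000 nM, most likely reported as a limit rather than a number.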

Compound 4, half-maximal inhibitory concentration: > 100000 nM
Compound 4 ended at the assay's limit; the forecaster's own chance of this, stated with the estimate: 85%; the middle value sits exactly at the limit.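

Compound 4, like compound 3, is recorded in this assay only as a limit, so no step can be read from compound 3 to compound 4, and the same holds from compound 1 to compound 2. The compounds shown leave open whether exchanging bromo for hydrogen changes the read-out at all, and what would yield a readable number; the evidence remains a single ceiling: the limit of > 100000 nM in this assay, at which 4 of the 4 values shown sit.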